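Dichloroacetanilides on KB cells: compound 3 to compound 4

The compounds below may be only part of what the source reports. "The series", "measured", "known", "first", "only" and "open" are said of these compounds alone.

Measured compounds:
compound 1 `Cc1ccccc1NC(=O)C(Cl)Cl`: "not determined" (no result reported)
compound 2 `Cc1cccc(NC(=O)C(Cl)Cl)c1`: "not determined" (no result reported)
compound 3 `N#Cc1cccc(NC(=O)C(Cl)Cl)c1`: 60900 nM

Among the measured compounds shown here, the three measured members share the dichloroacetamide core with one substituent on the aromatic ring. In a functional assay on KB cells (Homo sapiens) for antiproliferative activity, read by MTT assay, with a stated time of 72 h (on this read-out lower numbers stand for stronger inhibition and higher numbers for weaker inhibition), compound 1 gives "not determined" (no result reported). In this assay compound 2 likewise gives "not determined" (no result reported). For the measured compounds named here, only compound 3 carries a number: in this assay compound 3 gives 60900 nM, which is the single value and places it at the weak end of any useful range. Going by the values given here, no pair of measured compounds differs in one place, so no step size can be read off.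

Compound 4 `O=C(Nc1cccc(OC(F)(F)F)c1)C(Cl)Cl` is the next entry, not yet measured. It differs from compound 3 by trifluoromethoxy in place of cyano on an aromatic carbon, in words trifluoromethoxy in place of cyano on an aromatic carbon. Among the compounds with values here, with no step between measured compounds to lean on, the expectation is that the change from compound 3 to compound 4 stays within the scatter or is at most a small move in either direction, the estimated step being a 1.5-fold lower number from compound 3 to compound 4 (0.18 log units; within the scatter). For compound 4 in this assay the expected value is 40000 nM, with a range from 10000 nM to 150000 nM.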

Compound 4, half-maximal inhibitory concentration: 7410 nM
The estimate for compound 4 lay 5.4-fold (0.73 log units) above the measured number, and the stated range ends above it.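

Trifluoromethoxy in place of cyano on an aromatic carbon gives an 8.2-fold lower number from compound 3 to compound 4 (0.91 log units; beyond the scatter) in this assay, the first step that can be read in this series. The aromatic carbon carrying this group is therefore not a silent place: with the shared core unchanged, replacing the cyano group alone moves the number beyond the usual scatter, though the step is only modest and compound 4 at 7410 nM still sits in the micromolar range. Nothing measured here bears on what lies behind this step, so the result stands as an observation on one pair.

Steps to compound 1 and compound 2 cannot be read, so the series rests on a single comparison and gives no trend across substituents. From the compounds shown here alone, whether an amine, a carboxylic acid or a longer chain on the same aromatic carbon would lower the number further, leave it unchanged or raise it remains open, as does whether any change to the dichloroacetamide part would move it at all.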